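Swapping amino for methoxy on a piperidine side chain

A few compounds are considered here, and "the series" means these few. Any claim that something is new, unique, unknown or untested is made for them only; others in the source may bear on it.

Measured so far:
- compound 1 `CCCCCOC(=O)N1CCN(C(=O)[C@H](CCC(=O)O)NC(=O)c2cc(N3CCC(COC)CC3)nc(-c3ccccc3)n2)CC1`: 0.015 h
- compound 2 `CCCCCOC(=O)N1CCN(C(=O)[C@H](CCC(=O)O)NC(=O)c2nc(-c3ccccc3)cc(N3CCC(CN)CC3)n2)CC1`: 0.00333 h

Both compounds were tested in an in vivo ADME assay on the whole organism (strain Sprague-Dawley) for metabolic stability, with Rattus norvegicus as the target; on this read-out lower numbers stand for a shorter-lived compound and higher numbers for a longer-lived compound. Compound 2 has the lowest of the two numbers; compound 1 sits higher, and that gap is beyond the scatter. For the measured compounds named here, no step between the two is described, because they differ in more than one place.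

Compound 3 `CCCCCOC(=O)N1CCN(C(=O)[C@H](CCC(=O)O)NC(=O)c2nc(-c3ccccc3)cc(N3CCC(COC)CC3)n2)CC1` has not yet been measured. It is reached from compound 2 by one change: methoxy in place of amino on a saturated chain carbon bound to a saturated ring carbon. Going by the values given here, no measured pair shows this exact change on this core, so its effect is not known. The expectation rests on compound 1, which carries the same methoxymethyl group and gives 0.015 h in this assay. For compound 3 an upward step is therefore expected, a 2.4-fold higher number from compound 2 to compound 3 (0.38 log units; beyond the scatter), though it could also fall within the scatter. The estimate for compound 3 is 0.008 h, with a range from 0.003 h to 0.025 h.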

Compound 3, half-life: 0.005 h
Estimate against measurement, compound 3: 1.6-fold (0.20 log units) above; the measured number falls inside the stated range.
By their numbers in this assay, from the lowest: compounds 2 and 3 (each within the scatter of the next); then compound 1.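

In this assay, for the compounds shown here, the one direct comparison at this position gives a 1.5-fold higher number from compound 2 to compound 3 (0.18 log units; within the scatter). On this core, then, putting methoxy in place of amino on a saturated chain carbon bound to a saturated ring carbon does not clearly separate the two compounds, even though the amino group carries a hydrogen-bond donor and methoxy carries none. No supporting measurement is available to explain this result.

On these data alone, it remains open whether a hydroxyl group, an amide or a longer chain at this place would give a number beyond the scatter of compound 2. Also unresolved is whether a change elsewhere on the shared core would shift the half-life further than this swap does.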